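Compound 1 trades its carboxy group for an ethoxycarbonyl

A few compounds are considered here, and "the series" means these few. Any claim that something is new, unique, unknown or untested is made for them only; others in the source may bear on it.

In a functional assay on MCF7 cells (Homo sapiens) for inhibition, read by MTT assay, with a stated time of 3 days (on this read-out lower numbers stand for stronger inhibition and higher numbers for weaker inhibition), compound 1 (`CC[C@H](C)[C@@H](NCC(=O)NNC(=O)COc1ccc(-c2nc3ccccc3s2)cc1OC)C(=O)O`) reads 1790 nM and compound 2 (`COc1cc(-c2nc3ccccc3s2)ccc1OCC(=O)NNC(=O)CN(C(C)=O)[C@@H](CS)C(=O)O`) reads 1750 nM while compound 3 (`COc1cc(-c2nc3ccccc3s2)ccc1OCC(=O)NNC(=O)CN[C@@H](CS(=O)(=O)O)C(=O)O`) reads 1870 nM so compound 1 stands among three numbers that cannot be put in order. Compound 4 (`CCOC(=O)CN(C)CC(=O)NNC(=O)COc1ccc(-c2nc3ccccc3s2)cc1OC`) has not yet been measured. It carries ((ethoxycarbonyl)methyl)(methyl)amino in place of (1-carboxy-2-methylbutyl)amino on a saturated chain carbon bound to a carbonyl carbon. Three measured steps alter this same end of the molecule (a 1.0-fold lower number from compound 1 to compound 2 (0.01 log units; within the scatter)) and (a 1.0-fold higher number from compound 1 to compound 3 (0.02 log units; within the scatter)) and (a 1.1-fold higher number from compound 2 to compound 3 (0.03 log units; within the scatter)). All of them stayed small, which suggests that this end can change widely without moving the number. Yet compounds 1, 2 and 3 all keep a carboxy group and compound 4 has none, so these steps guide the expectation only loosely. No step beyond the scatter is expected in this assay (a 1.0-fold higher number from compound 1 to compound 4 (0.00 log units; within the scatter)). For compound 4 the estimate is 1800 nM (expected range 750 nM to 4300 nM).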

Compound 4, half-maximal inhibitory concentration: 1980 nM
Estimate against measurement, compound 4: 1.1-fold (0.04 log units) below; low and high end bracket the measured number.
By their numbers in this assay, from the lowest: compounds 2, 1, 3 and 4 (each within the scatter of the next).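

In this assay, the three new comparisons are a 1.1-fold higher number from compound 1 to compound 4 (0.04 log units; within the scatter) and a 1.1-fold higher number from compound 3 to compound 4 (0.02 log units; within the scatter) and a 1.1-fold higher number from compound 2 to compound 4 (0.05 log units; within the scatter) as the ethoxycarbonyl-bearing group takes over this end of the molecule. The earlier compounds shown here all kept a carboxy group, whereas compound 4 has none, so at this position on a saturated chain carbon bound to a carbonyl carbon a free carboxy group is not required for a reading of this size. Nothing measured here explains why this end accepts such different groups.

Every group shown at this end is an open chain, so a ring placed here, such as a piperidine, remains untested in the compounds shown. A primary amide or a hydroxyl group at this end is also an open case, and so is any change to the shared core.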